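The compounds below may be only part of what the source reports. "The series", "measured", "known", "first", "only" and "open" are said of these compounds alone.

Of the compounds shown here, three share one core and have been tested in a toxicity assay on the whole organism (strain Icem-CET (SPF Caw)) for cytotoxicity, with Mus musculus as the target; on this read-out higher numbers stand for an effect only at larger amounts of compound and lower numbers for an effect already at smaller amounts. Compound 1 `C#CCNC(=O)/C(C)=C(\C)c1ccc(Br)cc1` gives 180 mg/kg in this assay. Compound 2 `C=CCNC(=O)/C(C)=C(\C)c1ccc(Br)cc1` gives 120 mg/kg. Compound 3 `C/C(C(=O)NC1CC1)=C(/C)c1ccc(Br)cc1` gives 100 mg/kg. Compound 2 thus holds the second highest of the three numbers; its nearest neighbour is reached by a 1.2-fold lower number from compound 2 to compound 3 (0.08 log units; within the scatter), its furthest by a 1.5-fold lower number from compound 1 to compound 2 (0.18 log units; within the scatter). The remaining measured step, a 1.8-fold lower number from compound 1 to compound 3 (0.26 log units; within the scatter), is likewise within the scatter, so the three numbers cannot be told apart with confidence.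

Compound 4 `C=CCNC(=O)/C(C)=C(\C)c1ccc(C)cc1` differs from compound 2 in a single place: methyl in place of bromo on an aromatic carbon. All three measured steps concern the group on the amide-type nitrogen and leave the aromatic ring unchanged, so none of them speaks to an exchange on the ring. For the measured compounds named here, no measured step covers this kind of change, and the data give no direction for it. With nothing pointing either way, the expected step is none beyond the scatter, that is no change at the digits printed from compound 2 to compound 4 (within the scatter). Compound 4 is therefore estimated at 120 mg/kg in this assay, with a range from 60 mg/kg to 240 mg/kg.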

Compound 4, dose for half-maximal effect: 100 mg/kg
Estimate against measurement, compound 4: 1.2-fold (0.08 log units) above; the measured number falls inside the stated range.
By their numbers in this assay, from the lowest: compounds 3, 4, 2 and 1 (each within the scatter of the next).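

In this assay, for the compounds shown here, methyl in place of bromo on the aromatic carbon para to a large group gives a 1.2-fold lower number from compound 2 to compound 4 (0.08 log units; within the scatter) and so provides the first measured step on the ring, as all the earlier steps concerned the group on the amide-type nitrogen. This exchange swaps one heavy atom for one heavy atom, bromine for carbon, and adds no hydrogen-bond donors or acceptors; the step lies within the scatter, so compound 4 cannot be told apart from compound 2. No available evidence bears on this result.

As far as these compounds go, whether an amine, a carboxylic acid or a longer chain at this ring position would shift the number beyond the scatter stays open. So does whether methyl in place of bromo gives a similar step when propargyl or cyclopropyl, rather than allyl, sits on the amide-type nitrogen.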